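This account rests on a few compounds, and the source may have more. Where it says the series, first, only, none or still open, it means among the compounds named here.

Measured compounds:
- compound 1 `CC1(C)CC(NC(=S)Nc2cccc(Cl)c2)c2cc(Br)ccc2O1`: 8000 nM
- compound 2 `CC1(C)CC(NC(=S)NCc2ccccc2)c2cc(Br)ccc2O1`: 29000 nM
- compound 3 `CC1(C)CC(NC(=O)Nc2cccc(Cl)c2)c2cc(F)ccc2O1`: 39000 nM

All three were run in a functional assay on U-373MG ATCC cells (Homo sapiens) for inhibition, read by MTT assay, with a stated time of 72 h; on this read-out higher numbers stand for weaker inhibition and lower numbers for stronger inhibition. Compound 1 gives 8000 nM in this assay. Compound 2 gives 29000 nM and compound 3 gives 39000 nM. Compound 3 stands highest of the three numbers, but its gap to compound 2 lies within the scatter, so no order between those two is claimed; its gap to compound 1 lies beyond the scatter. The difference between the core of compound 1 and the core of compound 3 is not broken down here.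

One structural change occurs twice in the set. Between compound 1 and compound 2 it reads benzyl in place of 3-chlorophenyl on an amide-type nitrogen and its measured step is a 3.6-fold higher number from compound 1 to compound 2 (0.56 log units; beyond the scatter). The same change, in the sense of the "leaves" and "enters" parts, carries compound 3 to compound 4 `CC1(C)CC(NC(=O)NCc2ccccc2)c2cc(F)ccc2O1`: benzyl in place of 3-chlorophenyl on an amide-type nitrogen. The two places are not identical: in compound 1 the nitrogen's other neighbour is a thiocarbonyl carbon, in compound 3 it is a carbonyl carbon, so this is the same kind of change rather than the same change.

Among the measured compounds shown here, the expectation for compound 4 rests on the single measured precedent, the step from compound 1 to compound 2 a 3.6-fold higher number from compound 1 to compound 2 (0.56 log units; beyond the scatter), applied to the value of compound 3 39000 nM. For the measured compounds named here, with only one precedent and a different neighbour at the place, the expected step from compound 3 to compound 4 in this assay is a 2.8-fold higher number from compound 3 to compound 4 (0.45 log units; beyond the scatter), carrying wide uncertainty. The estimated value for compound 4 in this assay is 110000 nM, with an expected range from 40000 nM to 300000 nM.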

Compound 4, half-maximal inhibitory concentration: 11000 nM
The estimate for compound 4 lay 10-fold (1.00 log units) above the measured number, outside the stated range (below it).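

In this assay the replacement of 3-chlorophenyl by benzyl on the amide-type nitrogen with a carbonyl neighbour gives a 3.5-fold lower number from compound 3 to compound 4 (0.55 log units; beyond the scatter) and so runs against the earlier result on the thiocarbonyl series. The size of the step is similar on the two cores, but its direction reverses, so the effect of this change cannot be carried from one core to the other in this series: the same change on two cores in this assay, a 3.6-fold higher number (0.56 log units; beyond the scatter) from compound 1 to compound 2 and a 3.5-fold lower number (0.55 log units; beyond the scatter) from compound 3 to compound 4, 13-fold (1.11 log units) apart, beyond the scatter of two such steps.

Among the compounds shown here, this does not show which structural difference goes with the reversal, since the core of compound 1 and the core of compound 3 differ in both thiocarbonyl against carbonyl and bromine against fluorine, and each core offers only one pair.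

The compounds shown leave open whether the direction of the step follows the thiocarbonyl or carbonyl group or the halogen, a question that a matched pair combining thiocarbonyl with fluorine, or carbonyl with bromine, would address. Also open, as far as these compounds go, is how the series responds when the benzyl group gives way to a longer chain such as phenethyl, or when an amine or a carboxylic acid is placed on the aromatic ring.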